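Shorter tether on a nucleotide-linked alkylating series

The compounds below may be only part of what the source reports. "The series", "measured", "known", "first", "only" and "open" are said of these compounds alone.

Compound 1 `O=C(CI)NCCCCC(=O)NCCCCCCNc1ncnc2c1ncn2[C@@H]1O[C@H](COP(=O)(O)OP(=O)(O)OP(=O)(O)O)[C@@H](O)[C@H]1O`, compound 2 `CN(CCCCN(C)C(=O)CCCNc1ncnc2c1ncn2[C@@H]1O[C@H](COP(=O)(O)OP(=O)(O)OP(=O)(O)O)[C@@H](O)[C@H]1O)C(=O)CCCNC(=O)CI` and compound 3 `Nc1ncnc2c1nc(NCCCCNC(=O)CI)n2[C@@H]1O[C@H](COP(=O)(O)OP(=O)(O)OP(=O)(O)O)[C@@H](O)[C@H]1O` share the same core and carry the iodoacetyl group on tethers of differing length and attachment. In an assay on isolated protein for inhibition of hexokinase-1 (Rattus norvegicus), with a stated time of 6 h, tested at 10 mM (a higher number here means more inhibition at the concentration tested (going by the name of the read-out), a lower number less inhibition), compound 1 gives 0%; in this assay compound 2 gives 0% and compound 3 gives 0%. Compound 1 thus stands level with compound 2 and compound 3 at the digits shown, all within the scatter of one another.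

Compound 4 `O=C(CI)NCCCCCCCNc1ncnc2c1ncn2[C@@H]1O[C@H](COP(=O)(O)OP(=O)(O)OP(=O)(O)O)[C@@H](O)[C@H]1O` differs from compound 1 in the tether: a group of 6 heavy atoms (3 carbon, 1 nitrogen, 1 oxygen, 1 iodine; no ring) in place of a group of 12 heavy atoms (7 carbon, 2 nitrogen, 2 oxygen, 1 iodine; no ring), on a saturated chain carbon, six bonds along the chain from a nitrogen on an aromatic ring.

Among the compounds with values here, no step between measured compounds is available. With every measured value sitting at the floor of the scale, no step beyond the scatter is expected from compound 1 to compound 4. Compound 4 is expected to give 0% in this assay, with a range from 0% to 10%. The expected step is no change at the digits printed from compound 1 to compound 4 (within the scatter).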

Compound 4, a percentage reported as inhibition, at one concentration (the size of the read-out at that concentration, not a potency): 20%
Estimate against measurement, compound 4: 20 percentage points below; the measured number lies above the stated range.
By their numbers in this assay, from the lowest: compounds 1, 2 and 3 (each within the scatter of the next); then compound 4.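

In this assay, the (((iodomethyl)carbonyl)amino)methyl group in place of the larger group gives a number 20 percentage points higher from compound 1 to compound 4 (beyond the scatter), the only reading off the floor of the scale among the compounds shown. This position therefore responds to the change, which the level earlier compounds could not show. Nothing at hand bears on the origin of this step.

A single reading at one concentration leaves potency open. Also open, on these data alone, is whether an amine or a longer chain at this saturated chain carbon would keep, raise or lose the inhibition seen with compound 4.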